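Chloro on the Benzyl Ring: Compound 3 to Compound 4

The source may hold more compounds than are shown below. What is called first, only, known or untested is meant among the compounds shown, and "the series" means these compounds.

Compound 3 `CC1=C(C(=O)Nc2ccc(F)cc2)C(c2ccc([N+](=O)[O-])cc2)N=C(SCc2ccccc2)N1` gives 38.7% in a functional assay on the whole organism (artery, strain albino) with Rattus norvegicus as the target, with a stated time of 360 min, at a dose of 10 mg/kg by the oral route (on this read-out lower numbers stand for less inhibition and higher numbers for more inhibition at the one dose given (going by the name of the read-out)), the second highest of the three numbers: compound 2 `COc1ccc(C2N=C(SCc3ccccc3Cl)NC(C)=C2C(=O)Nc2ccc(F)cc2)cc1OC`, at 39.2%, lies within the scatter of it, while compound 1 `COc1ccc(C2N=C(SCc3ccccc3)NC(C)=C2C(=O)Nc2ccc(F)cc2)cc1OC`, at 3.6%, sits far below. Compound 4 `CC1=C(C(=O)Nc2ccc(F)cc2)C(c2ccc([N+](=O)[O-])cc2)N=C(SCc2ccccc2Cl)N1` is not yet measured; it differs from compound 3 by chloro in place of hydrogen on an aromatic carbon, on an aromatic carbon of a six-membered aromatic ring of carbon only. The same change has been made once before: a number 35.6 percentage points higher from compound 1 to compound 2 (beyond the scatter). The other measured step, a number 35.1 percentage points higher from compound 1 to compound 3 (beyond the scatter), reached the level of compound 2 by a different change. On these data alone, whether the two gains add is untested. A moderate further rise in this assay is expected for compound 4, a number 16.3 percentage points higher from compound 3 to compound 4 (beyond the scatter). Compound 4 is therefore estimated at 55%, between 35% and 75%.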

Compound 4, a percentage reported as inhibition, in the whole organism at one dose (the size of the read-out at that dose, not a potency): 21.6%
The estimate for compound 4 lay 33.4 percentage points above the measured number, outside the stated range (below it).
By their numbers in this assay, from the lowest: compound 1; then compound 4; then compounds 3 and 2 (each within the scatter of the next).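

Chloro in place of hydrogen on the benzyl ring now gives a number 17.1 percentage points lower from compound 3 to compound 4 (beyond the scatter), so in this assay this change has no constant direction across the two cores. 4-Nitrophenyl in place of 3,4-dimethoxyphenyl likewise turns downward when the chloro is present, a number 17.6 percentage points lower from compound 2 to compound 4 (beyond the scatter). The two changes do not add, and the outcome of each depends on the other: the same change on two cores in this assay, a number 35.6 percentage points higher (beyond the scatter) from compound 1 to compound 2 and a number 17.1 percentage points lower (beyond the scatter) from compound 3 to compound 4, 52.7 percentage points apart, beyond the scatter of two such steps

On these data alone, whether bromo in place of chloro on the benzyl ring behaves the same way remains open. So does the outcome of this chloro change with an amine-bearing phenyl on the saturated ring carbon.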